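This account rests on a few compounds, and the source may have more. Where it says the series, first, only, none or still open, it means among the compounds named here.

Of the compounds shown here, three have been measured in a functional assay on A549 cells (Homo sapiens) for cytotoxicity, read by MTT assay, with a stated time of 68 h; a lower number here means a stronger inhibitor, a higher number a weaker inhibitor. Compound 1 (`COc1ccc(-c2cc(NC(=O)C(Cl)Cl)cc(-c3ccc(OC)cc3)c2)cc1`) gives 20800 nM in this assay and compound 3 (`COc1ccc(-c2cccc(NC(=O)C(Cl)Cl)c2)cc1`) gives 8530 nM in the same test. Compound 2 (`O=C(Nc1cccc(-c2ccsc2)c1)C(Cl)Cl`) reads > 50000 nM as a limit of the assay and not a number. Compound 3 therefore holds the lower of the two actual numbers, and compound 1 is its nearest neighbour. Among the compounds with values here, the only measured step, a 2.4-fold lower number from compound 1 to compound 3 (0.39 log units; beyond the scatter), is modest but beyond the scatter, and it puts hydrogen in place of 4-methoxyphenyl on an aromatic carbon. That step leaves one methoxy in place and so does not test the group now at issue.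

Compound 4 (`Cc1ccc(-c2cccc(NC(=O)C(Cl)Cl)c2)cc1`) has methyl in place of methoxy on an aromatic carbon, para to a large group (methyl in place of methoxy on an aromatic carbon). Within the data shown here, no measured step changes this group, so in this assay no step beyond the scatter is expected in either direction. The estimate is a 1.2-fold higher number from compound 3 to compound 4 (0.07 log units; within the scatter), which is expected to stay small. For compound 4 the expected value is 10000 nM, with an estimated range from 4500 nM to 25000 nM in this test.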

Compound 4, half-maximal inhibitory concentration: 8300 nM
Compound 4: middle estimate off by 1.2-fold (0.08 log units), on the high side, within the range that was stated.
By their numbers in this assay, from the lowest: compounds 4 and 3 (each within the scatter of the next); then compound 1. At a limit, above all of these: compound 2.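

In this assay, methyl in place of methoxy on an aromatic carbon, para to a large group, gives a 1.0-fold lower number from compound 3 to compound 4 (0.01 log units; within the scatter) and so leaves the two compounds indistinguishable in this test. Within the data shown here, this is the first measured change to that group, since the earlier step, a 2.4-fold lower number from compound 1 to compound 3 (0.39 log units; beyond the scatter), removed a whole 4-methoxyphenyl and left the other methoxy untouched. For this pair, then, the hydrogen-bond acceptor counted in the methoxy can go without the number moving beyond the scatter, although nothing given here explains why the two compounds read alike.

On these data alone, the result covers only methoxy and methyl at this place, so how an amine, a carboxylic acid or a longer chain there would read in this assay stays open. Among these compounds, it also remains open whether the same exchange would be as silent on the core of compound 1, where a second 4-methoxyphenyl is present, because only the single pair of compound 3 and compound 4 carries this change.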